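Notes on the amine change from compound 3 to compound 4

The compounds below may be only part of what the source reports. "The series", "measured", "known", "first", "only" and "open" are said of these compounds alone.

All three measured compounds share one core and differ only in the amine on the saturated ring carbon. In an assay on CHO cells for displacement of a labelled ligand from 5-hydroxytryptamine receptor 1B (Homo sapiens) (on this read-out lower numbers stand for stronger inhibition and higher numbers for weaker inhibition), compound 3 `CC(C)=CCN(C)C1CCN(CCCc2c[nH]c3ccc(-n4cnnc4)cc23)CC1` gives 41 nM. Compound 1 `CC(C)=CCCN(C)C1CCN(CCCc2c[nH]c3ccc(-n4cnnc4)cc23)CC1` gives 24 nM and compound 2 `CC(=O)Nc1ccc(CNC2CCN(CCCc3c[nH]c4ccc(-n5cnnc5)cc34)CC2)cc1` gives 45 nM in this assay. Compound 3 thus holds the second highest of the three numbers, with both others within the scatter of it. Going by the values given here, the only step measured within this set, a 1.7-fold higher number from compound 1 to compound 3 (0.23 log units; within the scatter), exchanges one alkenyl chain for another and stays within the scatter, so it offers little guidance on a change of the present kind. Compound 4 `c1cncc(CNC2CCN(CCCc3c[nH]c4ccc(-n5cnnc5)cc34)CC2)c1` differs from compound 3 by ((pyridin-3-yl)methyl)amino in place of methyl(3-methylbut-2-en-1-yl)amino on a saturated ring carbon. Among the compounds with values here, no measured step covers this exchange; the closest reference is compound 2, whose amine also carries an aromatic ring attached through a saturated carbon and which gives 45 nM, within the scatter of compound 3. Compound 4 is therefore expected to give about 40 nM, with a range of 15 nM to 120 nM. The step of a 1.0-fold lower number from compound 3 to compound 4 (0.01 log units; within the scatter) is expected to remain within the scatter.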

Compound 4, half-maximal inhibitory concentration: 140 nM
For compound 4 the middle estimate is 3.5-fold (0.54 log units) below the measured one; measured number outside the range, above it.
By their numbers in this assay, from the lowest: compounds 1, 3 and 2 (each within the scatter of the next); then compound 4.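

In this assay, going by these compounds alone, the amine on the saturated ring carbon proves able to shift the number beyond the scatter, both for the change from a tertiary alkenyl amine (a 3.4-fold higher number from compound 3 to compound 4 (0.53 log units; beyond the scatter)) and for the longer alkenyl chain (a 5.8-fold higher number from compound 1 to compound 4 (0.77 log units; beyond the scatter)), whereas the one earlier step, between two alkenyl chains, stayed within it. An aromatic ring on the saturated chain carbon bound to an amine nitrogen does not by itself fix the number: pyridin-3-yl in place of 4-acetamidophenyl also gives a step beyond the scatter (a 3.1-fold higher number from compound 2 to compound 4 (0.49 log units; beyond the scatter)), so the group on that carbon counts even with the amine hydrogen kept. Nothing available bears on the reason for these steps.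

Compound 4 exchanges two features at once relative to compound 3, so the share of the ring and the share of the lost methyl on the amine nitrogen remain unseparated. A methyl((pyridin-3-yl)methyl)amino or a benzylamino group on the same carbon would divide them.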